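A few compounds are considered here, and "the series" means these few. Any claim that something is new, unique, unknown or untested is made for them only; others in the source may bear on it.

Series notes. Read-out throughout is a functional assay on the whole organism (strain Wistar albino) for inhibition, with Rattus norvegicus as the target, read by paw edema, with stated times of 30 min and 1 h, at a dose of 20 mg/kg by the oral route; a lower number here means less inhibition, a higher number more inhibition at the dose given (going by the name of the read-out).

compound 1 `Cc1nn2c(C(C)c3ccc(CC(C)C)cc3)nnc2s1`: 43%
compound 2 `CCc1nn2c(C(C)c3ccc(CC(C)C)cc3)nnc2s1`: 22%
compound 3 `CC(C)Cc1ccc(C(C)c2nnc3sc(-c4ccc(Br)cc4)nn23)cc1`: 58%

Compound 3 carries the highest of the three numbers in this assay; compound 1 stands nearest and compound 2 furthest, both gaps beyond the scatter. The two steps that lead into compound 3 are a number 15 percentage points higher from compound 1 to compound 3 (beyond the scatter) and a number 36 percentage points higher from compound 2 to compound 3 (beyond the scatter), each replacing a short alkyl group on the same aromatic carbon with 4-bromophenyl. The remaining step, a number 21 percentage points lower from compound 1 to compound 2 (beyond the scatter), runs on a different part of the molecule and does not bear on the change considered here.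

Compound 4 `CC(C)Cc1ccc(C(C)c2nnc3sc(-c4ccco4)nn23)cc1` has not been measured. Its change from compound 3 is furan-2-yl in place of 4-bromophenyl on an aromatic carbon. Within the data shown here, both informative steps point to an aromatic ring at this position being associated with the higher read-out, but no measured step compares one aromatic ring with another, so the direction is uncertain. The expectation is a modest downward step, a number 10 percentage points lower from compound 3 to compound 4 (within the scatter), with a wide band around it. Compound 4 is estimated at 48%, between 30% and 65%.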

Compound 4, a percentage reported as inhibition, in the whole organism at one dose (the size of the read-out at that dose, not a potency): 18%
Compound 4: middle estimate off by 30 percentage points, on the high side, outside the stated range (below it).
By their numbers in this assay, from the lowest: compounds 4 and 2 (each within the scatter of the next); then compound 1; then compound 3.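

In this assay an aromatic ring at this position does not by itself go with the higher read-out: furan-2-yl in place of 4-bromophenyl gives a number 40 percentage points lower from compound 3 to compound 4 (beyond the scatter). Set against the short alkyl groups, furan-2-yl gives a number 25 percentage points lower from compound 1 to compound 4 (beyond the scatter) and a number 4 percentage points lower from compound 2 to compound 4 (within the scatter), so among the groups shown the high number belongs to 4-bromophenyl alone, not to aromatic rings in general. Nothing available here accounts for the gap between the two rings.

Open, going by these compounds, is whether the bromine or the six-membered carbon ring goes with the higher number; a plain phenyl at this place would separate the two. Also open, on these data alone, is whether thiophen-2-yl, another five-membered aromatic ring, would follow furan-2-yl or 4-bromophenyl.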